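Replacing benzyloxy with bromo on the shared core

The compounds below may be only part of what the source reports. "The series", "measured", "known", "first", "only" and "open" are said of these compounds alone.

Measured so far in an ADME assay on Vero cells (Chlorocebus sabaeus) for cytotoxicity, read by MTT assay, with a stated time of 72 h (a lower number here means that less compound is needed, a higher number that more compound is needed for the effect), for this series:
- compound 1 `O=C(Nc1nc(-c2ccccn2)cs1)c1cccc(OCc2ccccc2)c1` gives 14400 nM
- compound 2 `COc1ccccc1C(=O)Nc1nc(-c2ccccn2)cs1` gives 43500 nM

Compound 1 holds the lower of the two numbers in this assay and compound 2 stands above it, by a gap beyond the usual scatter. Going by the values given here, no step in a single place links these two compounds.

Next is compound 3 `O=C(Nc1nc(-c2ccccn2)cs1)c1cccc(Br)c1` in which bromo replaces the benzyloxy of compound 1 on an aromatic carbon, meta to a large group bromo in place of benzyloxy on an aromatic carbon while the rest of the structure stays the same. Among the compounds with values here, no measured step covers this change, so the expectation is weak. Within the data shown here, the only guide is compound 2 at 43500 nM which also lacks benzyloxy and shows a higher number than compound 1, though it carries a different group. A modest rise in the number is therefore expected, possibly not beyond the scatter. The estimated step is a 1.7-fold higher number from compound 1 to compound 3 (0.22 log units; within the scatter) in this assay and its direction remains uncertain. For compound 3 the expected value is 24000 nM with 10000 nM to 60000 nM as the estimated range.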

Compound 3, half-maximal effective concentration: 16100 nM
The estimate for compound 3 lay 1.5-fold (0.17 log units) above the measured number; low and high end bracket the measured number.
By their numbers in this assay, from the lowest: compounds 1 and 3 (each within the scatter of the next); then compound 2.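

In this assay, going by these compounds alone, the first step in a single place reads a 1.1-fold higher number from compound 1 to compound 3 (0.05 log units; within the scatter), with bromo in place of benzyloxy on an aromatic carbon, meta to a large group. This position therefore tolerates a large reduction in the substituent without a change beyond the scatter: benzyloxy, with 8 heavy atoms, a six-membered aromatic ring and 1 hydrogen-bond acceptor, gives way to bromo, with 1 heavy atom, no ring and no hydrogen-bond acceptor, so neither that ring nor that acceptor is shown to be needed here for the number in this assay. Nothing measured on these compounds bears on the cause of this result.

On these data alone, whether this tolerance extends beyond these two groups remains open, since a primary amine, a carboxylic acid or a longer alkyl chain at the same place could give a number that departs from those of compound 1 and compound 3. Compound 2 differs from both in more than one place, so the changes behind its separate standing in the series remain unassigned.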